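The source may hold more compounds than are shown below. What is called first, only, known or untested is meant among the compounds shown, and "the series" means these compounds.

In a functional assay on SW480 cells (Homo sapiens) for antiproliferative activity, read by MTT assay, with a stated time of 48 h (a lower number here means a stronger inhibitor, a higher number a weaker inhibitor), compound 3 `CCN(CC)C/C1=C/C[C@](C)(CCC=C(C)C)/C=C/[C@@H](OC(=O)C=C(C)C)[C@](C)(O)/C=C/C1=O` gives 270 nM, close to compound 2 `CC(C)=CCC[C@]1(C)/C=C/[C@@H](OC(=O)C=C(C)C)[C@](C)(O)/C=C/C(=O)/C(CCl)=C\C1` at 390 nM, and both sit well under compound 1 `COC/C1=C/C[C@](C)(CCC=C(C)C)/C=C/[C@@H](OC(=O)C=C(C)C)[C@](C)(O)/C=C/C1=O` at 3850 nM. Compound 4 `CC[Si](CC)(CC)C/C1=C/C[C@](C)(CCC=C(C)C)/C=C/[C@@H](OC(=O)C=C(C)C)[C@](C)(O)/C=C/C1=O` changes compound 3 at one place: a group of 7 heavy atoms (6 carbon, 1 silicon; no ring) in place of a group of 5 heavy atoms (4 carbon, 1 nitrogen; no ring), on a saturated chain carbon bound to a double-bonded ring carbon. The relevant steps are at this same place: a 14-fold lower number from compound 1 to compound 3 (1.15 log units; beyond the scatter) and a 9.9-fold lower number from compound 1 to compound 2 (0.99 log units; beyond the scatter), both beyond the scatter, and a 1.4-fold lower number from compound 2 to compound 3 (0.16 log units; within the scatter), within it. The place is therefore sensitive to substitution, but no measured group there contains silicon, so direction and size remain uncertain. A modest rise in this assay is expected, with a 2.2-fold higher number from compound 3 to compound 4 (0.35 log units; beyond the scatter) as the estimated step. For compound 4 the estimated value is 600 nM, with an expected range of 150 nM to 3000 nM.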

Compound 4, half-maximal inhibitory concentration: 2690 nM
Estimate against measurement, compound 4: 4.5-fold (0.65 log units) below; the measured number falls inside the stated range.
By their numbers in this assay, from the lowest: compounds 3 and 2 (each within the scatter of the next); then compounds 4 and 1 (each within the scatter of the next).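

In this assay, the group of 7 heavy atoms (6 carbon, 1 silicon; no ring) on a saturated chain carbon bound to a double-bonded ring carbon loses much of the activity seen with diethylamino, a 10-fold higher number from compound 3 to compound 4 (1.00 log units; beyond the scatter), and with chloro, a 6.9-fold higher number from compound 2 to compound 4 (0.84 log units; beyond the scatter), while against methoxy the step, a 1.4-fold lower number from compound 1 to compound 4 (0.16 log units; within the scatter), stays within the scatter. Heavy-atom count alone therefore does not order these groups: compound 2 and compound 3 lie within the scatter of each other, as do compound 1 and compound 4. No evidence on the cause of these steps is at hand.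

Open, going by these compounds, is whether piperidine or morpholine at this place holds the level of compound 3, and whether an all-carbon triethylmethyl group behaves like the silicon group.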